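The source may hold more compounds than are shown below. What is called first, only, known or untested is meant among the compounds shown, and "the series" means these compounds.

Compound 3 `CSc1c(C)c(-c2ccccc2)c(C#N)c(N)c1C#N` is the compound with the higher of the two numbers available: in an assay on isolated protein for inhibition of glucose-6-phosphatase catalytic subunit 1 (Homo sapiens), tested at 100 uM (on this read-out lower numbers stand for less inhibition and higher numbers for more inhibition at the one concentration tested (going by the name of the read-out)), compound 3 gives 45%. Compound 2 `CSc1c(C#N)c(N)c(C#N)c(C)c1-c1ccccc1F` gives 20% in this assay, a smaller number, and the gap between the two lies beyond the usual scatter. Compound 1 `CSc1c(C#N)c(N)c(C#N)c(-c2ccccc2)c1-c1ccccc1` was reported in this assay only as "not active" (no number reported), with no number attached. Compound 4 `CSc1c(C)c(-c2ccc(Cl)cc2)c(C#N)c(N)c1C#N` has not yet been measured; it differs from compound 3 in one place: chloro in place of hydrogen on an aromatic carbon. Among the measured compounds shown here, no step between measured compounds tells what such a change does here, so the expected step from compound 3 to compound 4 is no change at the digits printed from compound 3 to compound 4 (within the scatter), nothing beyond the scatter. Compound 4 is therefore expected to give about 45% in this assay, within 20% to 70%.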

Compound 4, a percentage reported as inhibition, at one concentration (the size of the read-out at that concentration, not a potency): 12.5%
Estimate against measurement, compound 4: 32.5 percentage points above; measured number outside the range, below it.
By their numbers in this assay, from the lowest: compounds 4 and 2 (each within the scatter of the next); then compound 3.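

Among the compounds shown here, on this ring the position is not indifferent to substitution: in this assay, going from phenyl to 4-chlorophenyl gives a number 32.5 percentage points lower from compound 3 to compound 4 (beyond the scatter) and no earlier pair of compounds could show this. A single chloro, para to a large group, is thus enough to lower the inhibition read at the one concentration tested. Nothing measured here accounts for the size of this step.

As far as these compounds go, whether any group at this carbon lowers the number, or chloro in particular, remains open. A methoxy group or an amine at the same place would help separate these two readings.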